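Varying the chain amine in the antiproliferative series

This account rests on a few compounds, and the source may have more. Where it says the series, first, only, none or still open, it means among the compounds named here.

compound 1: `CCCN(CCC)CCCOc1ccc2cc(NC(=O)c3ccc(O)c(CC=C(C)C)c3)c(=O)oc2c1C` — > 50000 nM
compound 2: `CC(C)=CCc1cc(C(=O)Nc2cc3ccc(OCCCN(C(C)C)C(C)C)c(C)c3oc2=O)ccc1O` — 1600 nM

In a functional assay on SK-BR-3 cells (Homo sapiens) for antiproliferative activity (on this read-out higher numbers stand for weaker inhibition and lower numbers for stronger inhibition), compound 1 reaches only a limit, > 50000 nM. Compound 2 gives 1600 nM in this assay; it holds the only real number shown. Among the measured compounds shown here, the single measured step, an at least 31-fold lower number from compound 1 to compound 2 (1.49 log units; beyond the scatter), shows that the amine on this chain carbon moves the read-out strongly, and with compound 1 sitting at the limit of > 50000 nM in this assay, at which 1 of the 2 values shown sits, the true size of that step stays open.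

Compound 3, `CC(C)=CCc1cc(C(=O)Nc2cc3ccc(OCCCNCC(=O)O)c(C)c3oc2=O)ccc1O`, has not yet been measured. It differs from compound 2 by (carboxymethyl)amino in place of diisopropylamino on a saturated chain carbon, three bonds along the chain from an oxygen on an aromatic ring. For the measured compounds named here, no measured step covers this exact swap; the only step that bears on it is the one from compound 1 to compound 2, which shows that a change at this place can be large. Compound 3 is therefore expected to give a higher number, that is weaker inhibition, than compound 2. For compound 3 the expected step is a 13-fold higher number from compound 2 to compound 3 (1.10 log units; beyond the scatter). The estimate for compound 3 in this assay is 20000 nM, between 3000 nM and 60000 nM, with a fair chance that only a limit is reported.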

Compound 3, half-maximal inhibitory concentration: 7570 nM
Compound 3: middle estimate off by 2.6-fold (0.42 log units), on the high side, and the stated range covers the measured number.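

With compound 3 the chain carbon carries a group with hydrogen-bond donors where diisopropylamino has none, and in this assay the result is a moderate loss rather than a collapse: a 4.7-fold higher number from compound 2 to compound 3 (0.67 log units; beyond the scatter). The same group still stands well clear of dipropylamino, an at least 6.6-fold lower number from compound 1 to compound 3 (0.81 log units; beyond the scatter), so the three amines now fall in an order, with diisopropylamino giving the lowest number, (carboxymethyl)amino the middle one and dipropylamino the highest, and the earlier pair alone could not place a third group within that span. Compound 1 remains a limit, so both steps that start from or lead to it give only a bound, and the true distance of compound 3 from compound 1 stays unknown: the limit of > 50000 nM in this assay, at which 1 of the 3 values shown sits.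

Open, from the compounds shown here alone, is whether the carboxylic acid or the secondary amine of (carboxymethyl)amino accounts for the difference from diisopropylamino, which a primary amine, a piperidine or the methyl ester of the same group at this carbon would help to separate. Going by these compounds, a longer chain between the aromatic oxygen and the amine also stays open, as does whether the order of the three groups holds with a change elsewhere on the shared core.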